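Urea series on the shared core: methyl position on the aryl ring

The source may hold more compounds than are shown below. What is called first, only, known or untested is meant among the compounds shown, and "the series" means these compounds.

Measured so far in a functional assay on T-24 cells (Homo sapiens) for antiproliferative activity, read by MTT assay, with a stated time of 48 h; a higher number here means a weaker inhibitor, a lower number a stronger inhibitor:
- compound 1, `Cc1ccc(NC(=O)Nc2cccc(CNc3nccnc3Cl)c2)cc1C`, 8930 nM
- compound 2, `Cc1ccc(NC(=O)Nc2cccc(CNc3nccnc3Cl)c2)cc1`, 9820 nM
- compound 3, `O=C(Nc1cccc(CNc2nccnc2Cl)c1)Nc1ccccc1Cl`, 6680 nM

All three numbers sit close together. Compound 2 gives 9820 nM; compound 1 lies within the scatter of it, shown by a 1.1-fold higher number from compound 1 to compound 2 (0.04 log units; within the scatter), and compound 3 also lies within the scatter of it, shown by a 1.5-fold lower number from compound 2 to compound 3 (0.17 log units; within the scatter), which is the widest of the three gaps. Going by the values given here, the remaining step, a 1.3-fold lower number from compound 1 to compound 3 (0.13 log units; within the scatter), is likewise within the scatter, so nothing among the measured compounds separates one aryl group on the amide-type nitrogen from another.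

Compound 4, `Cc1cccc(NC(=O)Nc2cccc(CNc3nccnc3Cl)c2)c1`, is not yet measured in this assay. It differs from compound 2 as follows: 3-methylphenyl in place of 4-methylphenyl on an amide-type nitrogen. Among the compounds with values here, the steps that bear on this are those that also alter the aryl group on the amide-type nitrogen, namely a 1.5-fold lower number from compound 2 to compound 3 (0.17 log units; within the scatter) and a 1.3-fold lower number from compound 1 to compound 3 (0.13 log units; within the scatter), and the one that removes a methyl, a 1.1-fold higher number from compound 1 to compound 2 (0.04 log units; within the scatter); none of them reached beyond the scatter. A change that only moves a methyl within the same aryl group is therefore expected to give no step beyond the scatter, in either direction.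

For compound 4 the expected value in this assay is 8500 nM, with a range from 4000 nM to 18000 nM; this corresponds to an expected step of a 1.2-fold lower number from compound 2 to compound 4 (0.06 log units; within the scatter).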

Compound 4, half-maximal inhibitory concentration: 9570 nM
Estimate against measurement, compound 4: 1.1-fold (0.05 log units) below; low and high end bracket the measured number.
By their numbers in this assay, from the lowest: compounds 3, 1, 4 and 2 (each within the scatter of the next).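

In this assay, moving the single methyl from 4-methylphenyl to 3-methylphenyl on the amide-type nitrogen gives no step beyond the scatter (a 1.0-fold lower number from compound 2 to compound 4 (0.01 log units; within the scatter)), so the earlier finding that aryl groups here cannot be told apart now extends to a change of methyl position alone. Compound 4 also stays within the scatter of the two compounds with other aryl groups, both the 3,4-dimethylphenyl compound (a 1.1-fold higher number from compound 1 to compound 4 (0.03 log units; within the scatter)) and the 2-chlorophenyl compound (a 1.4-fold higher number from compound 3 to compound 4 (0.16 log units; within the scatter)), so all four compounds form one band with no exception among them. Nothing on hand bears on why these four compounds read alike.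

The compounds shown carry only small methyl or chloro substituents on this aryl ring, so it remains open whether a carboxylic acid, an amine or a longer alkyl chain at the same place would give a step beyond the scatter. Also open, going by these compounds, is whether 2-methylphenyl would stay in the same band, which would complete the set of methyl positions and allow a direct comparison with the 2-chlorophenyl group of compound 3.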